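This account rests on a few compounds, and the source may have more. Where it says the series, first, only, none or still open, it means among the compounds named here.

Four compounds built on one shared core are compared here. Compound 1 `Cc1ccc2[nH]c(=O)c(CN(Cc3ccc(C(C)(C)C)cc3)C(C)c3ccc(F)cc3)cc2c1` is the starting point. In a toxicity assay on MDCK cells (Canis lupus familiaris) for cytotoxicity, read by crystal violet staining, with a stated time of 48 h (on this read-out higher numbers stand for lower toxicity in this test and lower numbers for higher toxicity in this test), compound 1 gives > 33000 nM, which is a limit of the assay rather than a number (the limit of > 33000 nM in this assay, at which 1 of the 3 values shown sits). Compound 2 `CC(C)c1ccc2[nH]c(=O)c(CN(Cc3ccc(C(C)(C)C)cc3)C(C)c3ccc(F)cc3)cc2c1` differs from compound 1 by isopropyl in place of methyl on an aromatic carbon, a change that brought an at least 2.5-fold lower number from compound 1 to compound 2 (0.40 log units; beyond the scatter). In this assay compound 2 gives 13100 nM. Compound 3 `Cc1ccc2[nH]c(=O)c(CN(Cc3ccc(C(C)(C)C)cc3)C(C)c3ccc(N(C)C)c(Cl)c3)cc2c1` carries a different group on the side chain: the difference from compound 1 is 3-chloro-4-(dimethylamino)phenyl in place of 4-fluorophenyl on a saturated chain carbon bound to an amine nitrogen and a saturated chain carbon, with an at least 3.3-fold lower number from compound 1 to compound 3 (0.52 log units; beyond the scatter). In this assay compound 3 gives 9800 nM. The values of compound 2 and compound 3 lie within the usual scatter of each other.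

Compound 4 `CC(C)c1ccc2[nH]c(=O)c(CN(Cc3ccc(C(C)(C)C)cc3)C(C)c3ccc(N(C)C)c(Cl)c3)cc2c1` has not yet been measured. It differs from compound 3 by isopropyl in place of methyl on an aromatic carbon, the same change, at the same place on the core, that turned compound 1 into compound 2. Because an at least 2.5-fold lower number from compound 1 to compound 2 (0.40 log units; beyond the scatter) was seen for that change, a step of similar size is expected here, though the earlier step is only a lower bound. Compound 4 is therefore expected to give about 5000 nM, most likely between 2500 nM and 11000 nM. The expected step is a 2.0-fold lower number from compound 3 to compound 4 (0.29 log units; within the scatter).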

Compound 4, half-maximal cytotoxic concentration: > 10000 nM
Compound 4 was reported as a limit; the forecaster's own chance of this, stated with the estimate: 5%; middle value at least 2.0-fold (0.30 log units) from the limit.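

In this assay compound 4 gives > 10000 nM, which is a limit of the assay and not a number. On the core carrying the 3-chloro-4-(dimethylamino)phenyl group, isopropyl in place of methyl on an aromatic carbon gave an at least 1.0-fold higher number from compound 3 to compound 4 (0.00 log units; that floor lies within the scatter), while the steps that rest on two limits cannot be read. The lower number seen with the 4-fluorophenyl group therefore did not reappear as a measured lowering here, but this does not show that the change acts differently on the two cores: the same change on two cores in this assay, an at least 2.5-fold lower number (0.40 log units; beyond the scatter) from compound 1 to compound 2 and an at least 1.0-fold higher number (0.00 log units; that floor lies within the scatter) from compound 3 to compound 4; the limit leaves it open whether they differ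

The compounds shown leave open how far the true value of compound 4 lies from its limit, and with it the real size of the step. They also leave open whether a smaller or a different group at this aromatic carbon, such as ethyl or cyclopropyl, would give a readable step on both side chains.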